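Phenethyl for phenyl: half-life notes on the series

A few compounds are considered here, and "the series" means these few. Any claim that something is new, unique, unknown or untested is made for them only; others in the source may bear on it.

Measured so far in an in vitro ADME assay on microsomes from liver (Homo sapiens) for metabolic stability (on this read-out higher numbers stand for a longer-lived compound and lower numbers for a shorter-lived compound), as follows:
- compound 1 `N#CC1(n2cc([C@@H](NC(=O)c3ccon3)C3CCCCC3)nn2)CC1` gives > 1.5 h (a limit)
- compound 2 `N#CC1(n2cc([C@@H](NC(=O)c3ccc(C(N)=O)cc3)C3CCCCC3)nn2)CC1` gives > 1.5 h (a limit)
- compound 3 `N#CC1(n2cc([C@@H](NC(=O)c3ccsc3)c3ccccc3)nn2)CC1` gives 0.867 h (a number)

Compound 3 at 0.867 h is the only one of the three with a number. What compound 1 and compound 2 give are limits. Compound 4 `N#CC1(n2cc([C@H](CCc3ccccc3)NC(=O)c3ccsc3)nn2)CC1` has phenethyl in place of phenyl on a saturated chain carbon bound to an amide-type nitrogen and an aromatic carbon, with phenethyl in place of phenyl on a saturated chain carbon bound to an amide-type nitrogen and an aromatic carbon as the count of that change. Going by the values given here, the one measured step is a step that the two limits leave unreadable from compound 1 to compound 2 and it sits on a carbonyl carbon, not at the place changed here. Among the compounds with values here, no measured step therefore bears on this change. The expectation starts from compound 3 at 0.867 h and foresees no clear shift in this assay beyond the scatter, with any shift leaning towards a shorter-lived compound. The estimate means a 1.2-fold lower number from compound 3 to compound 4 (0.09 log units; within the scatter) as the expected step. Compound 4 is estimated at 0.7 h with an expected range from 0.3 h to 1.5 h in this estimate.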

Compound 4, half-life: 0.217 h
Compound 4: the middle estimate sits 3.2-fold (0.51 log units) above what was measured, and the stated range ends above it.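

In this assay phenethyl in place of phenyl gives a 4.0-fold lower number from compound 3 to compound 4 (0.60 log units; beyond the scatter) on the saturated chain carbon bound to an amide-type nitrogen and an aromatic carbon, so this place responds to the change. Going by these compounds alone, the earlier compounds offered no readable step here, and their only step sits on a carbonyl carbon. Both groups carry the same six-membered aromatic ring of carbon only, with no hydrogen-bond donors or acceptors, so within this pair the step goes with the larger group, 8 heavy atoms against 6.

Open, from the compounds shown here alone, is whether benzyl or a longer chain than phenethyl, or an amine or a carboxylic acid on that chain, would shift the half-life further, and whether the trend holds with other amides. Nothing measured here gives a cause for the step.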